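This account rests on a few compounds, and the source may have more. Where it says the series, first, only, none or still open, it means among the compounds named here.

Measured in a functional assay on A549 cells (Homo sapiens) for inhibition, read by sulforhodamine B assay; on this read-out higher numbers stand for weaker inhibition and lower numbers for stronger inhibition:
- compound 1 `COC(=O)CC/C(C)=C/Cc1c(OC)c(C)c2c(c1OCC#CCN1CCN(c3ccc(C#N)cc3)CC1)C(=O)OC2`: > 50000 nM
- compound 2 `COC(=O)CC/C(C)=C/Cc1c(OC)c(C)c2c(c1OCC#CCN1CCN(C(c3ccc(F)cc3)c3ccc(F)cc3)CC1)C(=O)OC2`: 34100 nM

Compound 1 gives > 50000 nM, which is a limit of the assay and not a number. In this assay compound 2 gives a true number, 34100 nM. Compound 3 `COC(=O)CC/C(C)=C/Cc1c(OC)c(C)c2c(c1OCC#CCN1CCN(c3ccccc3F)CC1)C(=O)OC2` carries 2-fluorophenyl in place of 4-cyanophenyl on an amine nitrogen in a ring. For the measured compounds named here, no measured pair shows what this swap does, so only a small estimated change towards stronger inhibition is expected in this assay, an at least 1.2-fold lower number from compound 1 to compound 3 (0.09 log units; that floor lies within the scatter). For compound 3 the estimated value is 40000 nM, with an expected range from 15000 nM to 50000 nM.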

Compound 3, half-maximal inhibitory concentration: 45300 nM
Compound 3: the middle estimate sits 1.1-fold (0.05 log units) below what was measured, within the range that was stated.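

Putting 2-fluorophenyl in place of 4-cyanophenyl on the amine nitrogen in the ring gives an at least 1.1-fold lower number from compound 1 to compound 3 (0.04 log units; that floor lies within the scatter) in this assay, so this position can carry the new group and still return a true number. Compound 1 gives > 50000 nM, which is a limit of the assay and not a number. The full size of the step therefore cannot be read, because one end of it is such a limit: the limit of > 50000 nM in this assay, at which 1 of the 3 values shown sits.

As far as these compounds go, it remains open how a plain phenyl group or a carboxylic acid-bearing phenyl group on this nitrogen would read in this assay.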